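Extending the Ester Chain of Compound 2 with a Methoxy Group

The compounds below may be only part of what the source reports. "The series", "measured", "known", "first", "only" and "open" are said of these compounds alone.

Of the compounds shown here, two sharing one core have been measured in a functional assay (aorta) with Oryctolagus cuniculus as the target; on this read-out lower numbers stand for stronger inhibition and higher numbers for weaker inhibition. Compound 1, `COCCO/C(O)=C1\C(C)=NC(C)=C(C(=O)OCCCN2C(=O)c3ccccc3S2(=O)=O)C1c1ccccc1[N+](=O)[O-]`, gives 2.7 nM in this assay. Compound 2, `CCO/C(O)=C1\C(C)=NC(C)=C(C(=O)OCCCN2C(=O)c3ccccc3S2(=O)=O)C1c1ccccc1C(F)(F)F`, gives 0.8 nM in this assay, the lower of the two numbers, and its gap to compound 1 lies beyond the usual scatter. Because the two differ in more than one place, only their two values can be compared.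

Compound 3, `COCCO/C(O)=C1\C(C)=NC(C)=C(C(=O)OCCCN2C(=O)c3ccccc3S2(=O)=O)C1c1ccccc1C(F)(F)F`, is not yet measured. It differs from compound 2 by methoxy in place of hydrogen on a saturated chain carbon, two bonds along the chain from an oxygen on an unsaturated carbon, so the ethoxy becomes a 2-methoxyethoxy while everything else stays the same. For the measured compounds named here, with no measured pair showing this exact change, the step from compound 2 to compound 3 in this assay is expected to be small, a 1.5-fold higher number from compound 2 to compound 3 (0.18 log units; within the scatter), a change not clearly beyond the scatter in either direction. Compound 3 is therefore estimated at 1.2 nM in this assay, within a range from 0.4 nM to 4 nM.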

Compound 3, half-maximal inhibitory concentration: 1.4 nM
Compound 3: the middle estimate sits 1.2-fold (0.07 log units) below what was measured, within the range that was stated.
By their numbers in this assay, from the lowest: compounds 2, 3 and 1 (each within the scatter of the next, the first and the last beyond it).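

In this assay, for the compounds shown here, extending the ethoxy to a 2-methoxyethoxy with trifluoromethyl held fixed gives the first direct reading at this saturated chain carbon (a 1.8-fold higher number from compound 2 to compound 3 (0.24 log units; within the scatter)), so this change is tolerated here, with no shift clearly beyond the scatter. Going by these compounds alone, compound 3 also provides the first single-place comparison for trifluoromethyl in place of nitro on an aromatic carbon (a 1.9-fold lower number from compound 1 to compound 3 (0.29 log units; within the scatter)), and this step is also within the scatter, even though the two-place gap between compound 1 and compound 2 lies beyond it. There is no supporting evidence to explain either step.

Still open, as far as these compounds go, is how a longer chain, or a chain ending in an amine or a carboxylic acid, would behave at this place. Also open, from the compounds shown here alone, is how a chlorine or a nitrile would compare on the aromatic carbon.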